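The compounds below may be only part of what the source reports. "The series", "measured", "known", "first", "only" and "open" are said of these compounds alone.

Values in a functional assay on MGC-803 cells (Homo sapiens) for inhibition, read by sulforhodamine B assay (a lower number here means a stronger inhibitor, a higher number a weaker inhibitor), so far
compound 1 `O=C1C=C(NC2CCCC2)C(=O)c2c1nc1n2[C@H]2OC[C@@H](O)[C@H]2OC1` gives > 8000 nM (a limit of the assay, not a number)
compound 2 `COc1ccccc1NC1=CC(=O)c2nc3n(c2C1=O)[C@H]1OC[C@@H](O)[C@H]1OC3` gives 1630 nM
compound 3 `O=C1C=C(Nc2ccc(I)cc2)C(=O)c2c1nc1n2[C@H]2OC[C@@H](O)[C@H]2OC1` gives 1400 nM

Compound 3 sits within the scatter of compound 2, and both have exact values, unlike compound 1. Compound 4 `COc1cccc(NC2=CC(=O)c3nc4n(c3C2=O)[C@H]2OC[C@@H](O)[C@H]2OC4)c1` carries 3-methoxyphenyl in place of 4-iodophenyl on an amine nitrogen. Within the data shown here, the closest precedent is one substituted phenyl exchanged for another, which stayed within the scatter (a 1.2-fold lower number from compound 2 to compound 3 (0.07 log units; within the scatter)). The larger steps replaced cyclopentyl (an at least 4.9-fold lower number from compound 1 to compound 2 (0.69 log units; beyond the scatter); an at least 5.7-fold lower number from compound 1 to compound 3 (0.75 log units; beyond the scatter)), a change not made here. No step beyond the scatter is therefore expected in this assay, and the estimate is small (a 1.1-fold higher number from compound 3 to compound 4 (0.03 log units; within the scatter)). For compound 4 the expected value is 1500 nM, within an estimated range of 700 nM to 3500 nM.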

Compound 4, half-maximal inhibitory concentration: 1780 nM
For compound 4 the middle estimate is 1.2-fold (0.07 log units) below the measured one; the measured number falls inside the stated range.
By their numbers in this assay, from the lowest: compounds 3, 2 and 4 (each within the scatter of the next). At a limit, above all of these: compound 1.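

In this assay, 3-methoxyphenyl on the amine nitrogen cannot be told apart from either of the other two substituted phenyl groups: a 1.3-fold higher number from compound 3 to compound 4 (0.10 log units; within the scatter) and a 1.1-fold higher number from compound 2 to compound 4 (0.04 log units; within the scatter). Compound 4 also joins compound 2 and compound 3 in the gap from cyclopentyl, with an at least 4.4-fold lower number from compound 1 to compound 4 (0.65 log units; beyond the scatter). That step rests on a limit of the assay for compound 1, not a number: the limit of > 8000 nM in this assay, at which 1 of the 4 values shown sits.

Going by these compounds, it remains open whether a plain phenyl, a benzyl group or a pyridine ring on this nitrogen would read like compound 2, compound 3 and compound 4 or like compound 1. On these data alone, a carboxylic acid or an amine on the phenyl ring is equally open.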